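Benzoyl in Place of Phenylsulfonyl: an Expected Step

This account rests on a few compounds, and the source may have more. Where it says the series, first, only, none or still open, it means among the compounds named here.

Of the compounds shown here, three built on one shared core have been measured in a functional assay on MT4 cells (Homo sapiens) for antiproliferative activity, read by MTT assay, with a stated time of 96 h; a lower number here means that less compound is needed, a higher number that more compound is needed for the effect. Compound 1 `N#C/C(=C\c1c(-c2ccccc2)[nH]c2ccccc12)C(N)=O` gives 6000 nM in this assay. Compound 2 `N#C/C(=C\c1c(-c2ccccc2)[nH]c2ccccc12)C(=O)c1cccs1` gives 400 nM. Compound 3 `N#C/C(=C\c1c(-c2ccccc2)[nH]c2ccccc12)S(=O)(=O)c1ccccc1` gives 400 nM. Compound 3 therefore stands level with compound 2 at the digits reported, and the two together hold the lowest numbers of the three, while compound 1 lies well apart: a 15-fold lower number from compound 1 to compound 3 (1.18 log units; beyond the scatter), and in the same way a 15-fold lower number from compound 1 to compound 2 (1.18 log units; beyond the scatter). Between the two aryl-bearing compounds there is nothing to separate, as no change at the digits printed from compound 2 to compound 3 (within the scatter).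

Compound 4 `N#C/C(=C\c1c(-c2ccccc2)[nH]c2ccccc12)C(=O)c1ccccc1` differs from compound 3 in one place: benzoyl in place of phenylsulfonyl on a double-bonded chain carbon bound to a double-bonded chain carbon and a triple-bonded carbon. The step that bears most directly on this change is no change at the digits printed from compound 2 to compound 3 (within the scatter), which shows an aryl carbonyl and an aryl sulfone at this position yielding the same number. The two large steps, from compound 1, concern the loss of the carbamoyl group rather than the exchange of one aryl-bearing group for another, and compound 4 keeps an aryl carbonyl. Compound 4 is therefore expected to give about 400 nM in this assay, with a range from 150 nM to 1100 nM. The expected step is no change at the digits printed from compound 3 to compound 4 (within the scatter), not beyond the scatter.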

Compound 4, half-maximal effective concentration: 500 nM
Estimate against measurement, compound 4: 1.3-fold (0.10 log units) below, and the stated range covers the measured number.
By their numbers in this assay, from the lowest: compounds 2, 3 and 4 (each within the scatter of the next); then compound 1.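

The earlier step from the thiophene ketone to the sulfone exchanged the linking group and the ring together, and compound 4 now separates the two in this assay: with the phenyl ring kept, exchanging the sulfonyl link for a carbonyl gives a 1.3-fold higher number from compound 3 to compound 4 (0.10 log units; within the scatter), and with the carbonyl kept, exchanging the ring gives a 1.3-fold higher number from compound 2 to compound 4 (0.10 log units; within the scatter). The amide comparison can also now be read with a phenyl ring replacing the amino group on the same carbonyl carbon, as a 12-fold lower number from compound 1 to compound 4 (1.08 log units; beyond the scatter), so at this place compound 1 remains apart from three aryl-bearing compounds whose numbers cannot be told apart. No measurement at hand accounts for either the closeness of these three numbers or the distance of compound 1.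

The compounds shown leave open whether a carbonyl group carrying no ring, such as acetyl, or a methyl ester or a carboxylic acid, would stay with compounds 2, 3 and 4 or lie nearer compound 1. They also leave open what chloro, methoxy or an amine on the phenyl ring of the benzoyl group would do to the number in this assay.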